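Dimethylphenyl isomers in the benzyl sulfide series

The compounds below may be only part of what the source reports. "The series", "measured", "known", "first", "only" and "open" are said of these compounds alone.

Measured in a functional assay on DU-145 cells (Homo sapiens) for inhibition, read by trypan blue exclusion, with a stated time of 96 h; on this read-out lower numbers stand for stronger inhibition of growth and higher numbers for weaker inhibition of growth
- Compound 1 `O=C(/C(=C\c1c(O)cc(O)cc1O)SCc1ccc(Cl)cc1)c1ccc(Cl)cc1` gives > 100000 nM as a limit of the assay
- Compound 2 `Cc1cc(C)cc(/C=C(/Sc2ccc(Br)cc2)C(=O)c2ccc(Cl)cc2)c1` gives 10000 nM
- Compound 3 `Cc1ccc(C)c(/C=C(/SCc2ccc(Cl)cc2)C(=O)c2ccc(Cl)cc2)c1` gives 10000 nM

Compound 2 gives 10000 nM and compound 3 gives 10000 nM in this assay so the two stand level within the scatter. Compound 4 `Cc1cc(C)cc(/C=C(/SCc2ccc(Cl)cc2)C(=O)c2ccc(Cl)cc2)c1` has 3,5-dimethylphenyl in place of 2,5-dimethylphenyl on a double-bonded chain carbon bound to a double-bonded chain carbon, and 3,5-dimethylphenyl in place of 2,5-dimethylphenyl on a double-bonded chain carbon bound to a double-bonded chain carbon is the whole of the change from compound 3.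

Among the compounds with values here, the one measured step reaching compound 3 is an at least 10-fold lower number from compound 1 to compound 3 (1.00 log units; beyond the scatter) with 2,5-dimethylphenyl in place of 2,4,6-trihydroxyphenyl. That step removes a trihydroxyphenyl group, whereas the present change keeps the same atoms joined differently, so it sets no size for the present change. Compound 2 also carries 3,5-dimethylphenyl and gives 10000 nM in this assay with no gap to compound 3 at the digits shown, although it differs elsewhere. No step beyond the scatter is therefore expected, in either direction. The expected change is no change at the digits printed from compound 3 to compound 4 (within the scatter) on this evidence. For compound 4 the estimated value is 10000 nM with an expected range of 3000 nM to 30000 nM in this read-out.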

Compound 4, concentration for 50% growth inhibition: 10000 nM
Beside the measured number, compound 4's estimate shows no gap at the digits printed, and the stated range covers the measured number.
By their numbers in this assay, from the lowest: compounds 2, 3 and 4 (each within the scatter of the next). At a limit, above all of these: compound 1.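

In this assay, 3,5-dimethylphenyl in place of 2,5-dimethylphenyl on a double-bonded chain carbon bound to a double-bonded chain carbon gives no change at the digits printed from compound 3 to compound 4 (within the scatter), so this read-out does not separate the two isomers in the benzyl sulfide series. With 3,5-dimethylphenyl held constant, 4-chlorobenzyl in place of 4-bromophenyl on a sulfur gives no change at the digits printed from compound 2 to compound 4 (within the scatter), the first pair shown in which only the group on the sulfur differs. 3,5-dimethylphenyl in place of 2,4,6-trihydroxyphenyl gives an at least 10-fold lower number from compound 1 to compound 4 (1.00 log units; beyond the scatter), so the isomer repeats the direction seen with 2,5-dimethylphenyl, though this step is read against a limit and not a number: the limit of > 100000 nM in this assay, at which 1 of the 4 values shown sits.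

The compounds shown leave open whether any group at this position can bring the number below the level shared by compound 2, compound 3 and compound 4, since the dimethylphenyl isomers offer no spread to follow. Also open, from the compounds shown here alone, is how an amine or a carboxylic acid on this ring would compare, and whether the two sulfur groups would still stand level on a ring other than 3,5-dimethylphenyl.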